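Toward compound 3: exchanging the side chain on the shared core

This account rests on a few compounds, and the source may have more. Where it says the series, first, only, none or still open, it means among the compounds named here.

For the measured compounds named here, compound 2 `CN(C)CCN(C)c1ccc(C#N)c(CN2CCN(C(c3ccccc3)c3ccc(Cl)cc3)CC2)c1` gives a half-maximal cytotoxic concentration of 5660 nM in a toxicity assay on Huh-7.5 cells (Homo sapiens) for cytotoxicity, read by MTT assay, with a stated time of 96 h (a lower number here means that less compound is tolerated, a higher number that more compound is tolerated), the only true number so far. Compound 3 `N#Cc1ccc(NCCCn2ccnc2)cc1CN1CCN(C(c2ccccc2)c2ccc(Cl)cc2)CC1` carries (3-(1H-imidazol-1-yl)propyl)amino in place of (2-(dimethylamino)ethyl)(methyl)amino on an aromatic carbon, para to a cyano group ((3-(1H-imidazol-1-yl)propyl)amino in place of (2-(dimethylamino)ethyl)(methyl)amino on an aromatic carbon). Going by the values given here, no measured step gives the size of this change. A moderate rise in this assay, toward more compound tolerated, is expected, resting on compound 1 `N#Cc1ccc(NCCCn2ccnc2)cc1CN1CCN(C(c2ccccc2)c2ccccc2)CC1`, which holds the entering group and gives > 20000 nM, a limit of the assay and not a number. The estimate amounts to an expected step of a 2.1-fold higher number from compound 2 to compound 3 (0.33 log units; beyond the scatter). For compound 3 the expected value is 12000 nM, with an estimated range of 6000 nM to 25000 nM.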

Compound 3, half-maximal cytotoxic concentration: 5380 nM
Compound 3: the middle estimate sits 2.2-fold (0.35 log units) above what was measured; the whole stated range lies above it.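

On the shared core carrying the chloro group, (3-(1H-imidazol-1-yl)propyl)amino in place of (2-(dimethylamino)ethyl)(methyl)amino, on the aromatic carbon para to a cyano group, gives values within the scatter of each other in this assay: a 1.1-fold lower number from compound 2 to compound 3 (0.02 log units; within the scatter). For compound 1 the value is a limit of the assay and not a number: the limit of > 20000 nM in this assay, at which 1 of the 3 values shown sits.

With that limit in mind, chloro in place of hydrogen on an aromatic carbon gives an at least 3.7-fold lower number from compound 1 to compound 3 (0.57 log units; beyond the scatter), so the chloro exchange, not the side-chain exchange, is the step in this series that lies beyond the scatter.

Open, from the compounds shown here alone, is whether (2-(dimethylamino)ethyl)(methyl)amino gives the same reading on the core without the chloro group. Also open, going by these compounds, is how a fluoro or methoxy group in place of the chloro group, or a morpholine at the end of the side chain, would read.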